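Methylsulfanyl for Aminoamino on Two Related Cores

The source may hold more compounds than are shown below. What is called first, only, known or untested is meant among the compounds shown, and "the series" means these compounds.

Compound 1 `CSc1nc(-c2ccco2)c(C#N)c(=O)n1C`, compound 2 `Cn1c(NN)nc(-c2ccco2)c(C#N)c1=O` and compound 3 `Cn1c(NN)nc(-c2ccccc2Cl)c(C#N)c1=O` have been measured in a functional assay, with a stated time of 10 min; on this read-out lower numbers stand for stronger inhibition and higher numbers for weaker inhibition. Compound 1 gives 79 ug/mL, compound 2 gives 58 ug/mL, and compound 3 gives 46 ug/mL. The change between compound 2 and compound 1 is methylsulfanyl in place of aminoamino on an aromatic carbon, and the step it made was a 1.4-fold higher number from compound 2 to compound 1 (0.13 log units; within the scatter). The cores of compound 2 and compound 3 differ, but that difference is not broken down here. Compound 4 `CSc1nc(-c2ccccc2Cl)c(C#N)c(=O)n1C` has not yet been measured; it differs from compound 3 by methylsulfanyl in place of aminoamino on an aromatic carbon. This is the same kind of change as the earlier one, though there the place was meta to a furan-2-yl group (5 heavy atoms), while here it is meta to a group of 7 heavy atoms. The earlier step stayed within the scatter. On that basis compound 4 is expected to take a step of a 1.4-fold higher number from compound 3 to compound 4 (0.14 log units; within the scatter) in this assay. Compound 4 is thus estimated at 63 ug/mL, with a range from 30 ug/mL to 130 ug/mL.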

Compound 4, half-maximal inhibitory concentration: 67 ug/mL
Estimate against measurement, compound 4: 1.1-fold (0.03 log units) below; low and high end bracket the measured number.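

In this assay, methylsulfanyl in place of aminoamino on the core of compound 3 gave a 1.5-fold higher number from compound 3 to compound 4 (0.16 log units; within the scatter). Set beside the same change on the core of compound 2, the two steps agree: the same change on two cores in this assay, a 1.4-fold higher number (0.13 log units; within the scatter) from compound 2 to compound 1 and a 1.5-fold higher number (0.16 log units; within the scatter) from compound 3 to compound 4, 1.1-fold (0.03 log units) apart, within the scatter of two such steps. Across these two cores, then, the change carried over without any step beyond the scatter, but this does not show that the change itself has a real effect on inhibition, nor that it would carry over to any further core.

The compounds shown leave open whether a simple amine, a methoxy group or a longer alkylsulfanyl chain at this place would move the number beyond the scatter in this assay. They also leave open whether the change would behave alike on a core carrying a carboxylic acid instead of the cyano group.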